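Swapping Iodine for Fluorine on the Benzothiazole Amine

A few compounds are considered here, and "the series" means these few. Any claim that something is new, unique, unknown or untested is made for them only; others in the source may bear on it.

In a functional assay on Ca-Ski cells (Homo sapiens) for cytotoxicity, read by sulforhodamine B assay, with a stated time of 48 h (on this read-out lower numbers stand for stronger inhibition and higher numbers for weaker inhibition), compound 2 `O=c1cc(-c2ccccc2)oc2cc(OCCCCNc3nc4ccc(I)cc4s3)cc(O)c12` gives 13.2 ug/mL, and compound 1 `O=c1cc(-c2ccccc2)oc2cc(OCCCCNc3nc4ccccc4s3)cc(O)c12` gives 14.6 ug/mL; the two stand within the scatter of each other. For the measured compounds named here, the only step recorded so far, a 1.1-fold lower number from compound 1 to compound 2 (0.04 log units; within the scatter), is the one that bears on compound 3 `O=c1cc(-c2ccccc2)oc2cc(OCCCCNc3nc4ccc(F)cc4s3)cc(O)c12`, whose change from compound 2 is fluoro in place of iodo on an aromatic carbon. Since adding iodo to the shared core moved nothing beyond the scatter, its replacement by fluoro is expected to leave the number about where it is, giving a 1.1-fold higher number from compound 2 to compound 3 (0.03 log units; within the scatter). Compound 3 is therefore estimated at 14 ug/mL, with a range from 8 ug/mL to 25 ug/mL.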

Compound 3, half-maximal inhibitory concentration: 13.4 ug/mL
Compound 3: the middle estimate sits 1.0-fold (0.02 log units) above what was measured; the measured number falls inside the stated range.
By their numbers in this assay, from the lowest: compounds 2, 3 and 1 (each within the scatter of the next).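

In this assay the fluoro step adds a second halogen at this position, and it too moves nothing beyond the scatter (a 1.0-fold higher number from compound 2 to compound 3 (0.01 log units; within the scatter)), as does fluoro in place of hydrogen (a 1.1-fold lower number from compound 1 to compound 3 (0.04 log units; within the scatter)). Hydrogen, iodo and fluoro on this aromatic carbon therefore cannot be told apart by this read-out, which extends the earlier finding from one halogen to two. No supporting evidence bears on this result. As far as these compounds go, whether an amine or a carboxylic acid on this carbon would shift the number beyond the scatter remains open.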